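Solubility notes on the amine-tailed series

The source may report more compounds than this note shows. Statements on the series, on what has been measured and on what is new or still open speak of the compounds shown alone.

Measured so far:
compound 1, `NCCOc1ccc([C@H]2CC[C@]3(CC2)OOC2(O3)C3CC4CC(C3)CC2C4)cc1` — > 100 ug/mL
compound 2, `CC(C)(N)CCOc1ccc([C@H]2CC[C@]3(CC2)OOC2(O3)C3CC4CC(C3)CC2C4)cc1` — 50 ug/mL
compound 3, `NC1CCN(S(=O)(=O)c2ccc([C@H]3CC[C@]4(CC3)OOC3(O4)C4CC5CC(C4)CC3C5)cc2)CC1` — 12.5 ug/mL

In a physicochemical assay for solubility, read by nephelometry, measured as kinetic solubility, with a stated time of 30 min (a higher number here means a more soluble compound, a lower number a less soluble compound), compound 1 gives > 100 ug/mL, which is a limit of the assay rather than a number. Compound 2 gives 50 ug/mL and compound 3 gives 12.5 ug/mL.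

Compound 4 is `O[C@H]1CC[C@H](NCCCOc2ccc([C@H]3CC[C@]4(CC3)OOC3(O4)C4CC5CC(C4)CC3C5)cc2)CC1`. It differs from compound 1 by ((4-hydroxycyclohexyl)amino)methyl in place of amino on a saturated chain carbon, two bonds along the chain from an oxygen on an aromatic ring. Among the measured compounds shown here, no measured step makes this change. The closest is an at least 2.0-fold lower number from compound 1 to compound 2 (0.30 log units; that floor lies within the scatter), which alters the group at the same place and whose floor lies within the scatter. The steps of an at least 8.0-fold lower number from compound 1 to compound 3 (0.90 log units; beyond the scatter) and a 4.0-fold lower number from compound 2 to compound 3 (0.60 log units; beyond the scatter) exchange the whole aromatic substituent and bear only loosely on the change. Because compound 1 sits at the limit of > 100 ug/mL in this assay, at which 1 of the 3 values shown sits, a step from it can only be read downward.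

The expectation is a small downward step, an at least 1.6-fold lower number from compound 1 to compound 4 (0.22 log units; that floor lies within the scatter), possibly none beyond the scatter. Compound 4 is estimated at 60 ug/mL, within 20 ug/mL to 100 ug/mL, with a fair chance that the assay again reports only the limit.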

Compound 4, solubility: > 100 ug/mL
Compound 4: a limit, no number (the forecaster's own chance of this, stated with the estimate: 35%); middle value at least 1.6-fold (0.22 log units) away from the limit.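

In this assay compound 4 gives > 100 ug/mL, a limit of the assay and not a number, so this saturated chain carbon, two bonds along the chain from an oxygen on an aromatic ring, carries ((4-hydroxycyclohexyl)amino)methyl, with its six-membered non-aromatic ring of carbon only, without the read-out leaving the limit. The step between compound 1 and compound 4 cannot be read, as both ends are limits: the limit of > 100 ug/mL in this assay, at which 2 of the 4 values shown sit. The read-outs show an at least 8.0-fold higher number from compound 3 to compound 4 (0.90 log units; beyond the scatter), and an at least 2.0-fold higher number from compound 2 to compound 4 (0.30 log units; that floor lies within the scatter), so only the first of these stands clear of the scatter.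

As far as these compounds go, how far compound 1 and compound 4 lie past the limit stays unknown, so no ranking of the two is possible. From the compounds shown here alone, whether a morpholine or a carboxylic acid at this place on the chain would also stay at the limit remains open.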